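From Ethylsulfanyl to Dimethylamino on Compound 1

The source may report more compounds than this note shows. Statements on the series, on what has been measured and on what is new or still open speak of the compounds shown alone.

Of the compounds shown here, three have been measured in a functional assay on MV4-11 cells (Homo sapiens) for inhibition, read by resazurin assay, with a stated time of 72 h; on this read-out higher numbers stand for weaker inhibition of growth and lower numbers for stronger inhibition of growth. Compound 1 `CCSc1nc(C)c(-c2ccnc(Nc3ccc(OC)cc3OC)n2)s1` gives 32400 nM, the highest of the three numbers. Compound 2 `COc1ccc(N(C)c2nccc(-c3cn(C)c4ccccc34)n2)c(OC)c1` gives 2000 nM, and compound 3 `COc1ccc(Nc2nccc(-c3cn(C)c4ccccc34)n2)c(OC)c1` gives 3410 nM. Going by the values given here, the only single-site step among them, a 1.7-fold higher number from compound 2 to compound 3 (0.23 log units; within the scatter), concerns a different part of the molecule and lies within the scatter. Compound 4 `COc1ccc(Nc2nccc(-c3sc(N(C)C)nc3C)n2)c(OC)c1` differs from compound 1 by dimethylamino in place of ethylsulfanyl on an aromatic carbon. Among the compounds with values here, no measured pair shows the effect of this exchange, so there is no basis for expecting a shift beyond the scatter in either direction. Compound 4 is therefore estimated at 25000 nM, with a range from 5000 nM to 100000 nM. This estimate means an expected step of a 1.3-fold lower number from compound 1 to compound 4 (0.11 log units; within the scatter).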

Compound 4, concentration for 50% growth inhibition: 170 nM
Compound 4: the middle estimate sits 150-fold (2.17 log units) above what was measured; the measured number lies below the stated range.
By their numbers in this assay, from the lowest: compound 4; then compounds 2 and 3 (each within the scatter of the next); then compound 1.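

In this assay, this aromatic carbon proves highly sensitive to the group it carries: the exchange of ethylsulfanyl for dimethylamino gives a 190-fold lower number from compound 1 to compound 4 (2.28 log units; beyond the scatter) even though the heavy-atom count stays the same. Going by these compounds alone, the only earlier step, a 1.7-fold higher number from compound 2 to compound 3 (0.23 log units; within the scatter) on a nitrogen elsewhere, gave no sign of a change this large. No measurement available here accounts for this gain. Going by these compounds, it remains open whether the gain is specific to dimethylamino, or whether methylamino, diethylamino or morpholine at the same place would give a similarly low number.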